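The compounds below may be only part of what the source reports. "The series", "measured", "known", "first", "only" and "open" are said of these compounds alone.

Measured so far in a functional assay on MCF7 cells (Homo sapiens) for cytotoxicity, read by MTT assay, with a stated time of 4 h; on this read-out higher numbers stand for weaker inhibition and lower numbers for stronger inhibition:
- compound 1 `O=C1N=C(NN2Cc3ccccc3N=C2c2ccccc2)S/C1=C/c1ccc(Br)cc1`: 2300 nM
- compound 2 `O=C1N=C(NN2Cc3ccccc3N=C2c2ccccc2)S/C1=C/c1ccccc1`: 4050 nM
- compound 3 `CCc1ccc(NCC(=O)Nn2c(-c3ccccc3)nc3ccccc3c2=O)cc1`: 2420 nM

Compound 2 sits at the top end of the three numbers in this assay, but its separation from compound 1 and from compound 3 lies within the scatter, so the three are not distinguished.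

Compound 4 `COc1ccc(/C=C2/SC(NN3Cc4ccccc4N=C3c3ccccc3)=NC2=O)cc1`, not yet measured, differs from compound 2 by methoxy in place of hydrogen on an aromatic carbon. Within the data shown here, the one measured step that bears on this position is a 1.8-fold higher number from compound 1 to compound 2 (0.25 log units; within the scatter), a change at the same aromatic carbon that stayed within the scatter. On that basis a substituent at this place is not expected to move the number beyond the scatter, and the step of a 1.3-fold lower number from compound 2 to compound 4 (0.10 log units; within the scatter) is accordingly expected to be small. Compound 4 is therefore estimated at 3200 nM, with a range from 1200 nM to 8500 nM.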

Compound 4, half-maximal inhibitory concentration: 3760 nM
The estimate for compound 4 lay 1.2-fold (0.07 log units) below the measured number; the measured number falls inside the stated range.
By their numbers in this assay, from the lowest: compounds 1, 3, 4 and 2 (each within the scatter of the next).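

In this assay the change from phenyl to 4-methoxyphenyl gives a 1.1-fold lower number from compound 2 to compound 4 (0.03 log units; within the scatter) and methoxy in place of bromo gives a 1.6-fold higher number from compound 1 to compound 4 (0.21 log units; within the scatter). Hydrogen, bromo and methoxy on this aromatic carbon, para to a large group, are therefore not told apart, and the insensitivity seen with a halogen now extends to a group containing oxygen. Nothing available explains this lack of separation.

On these data alone, whether an amine, a carboxylic acid or a longer chain at this place would move the number beyond the scatter remains open. Also open, as far as these compounds go, is whether methoxy or bromo would behave the same way on another carbon of this ring.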